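The source may report more compounds than this note shows. Statements on the series, on what has been measured and on what is new or still open speak of the compounds shown alone.

Of the compounds shown here, two sharing one core have so far been measured in a functional assay (aorta) with Rattus norvegicus as the target; on this read-out higher numbers stand for weaker inhibition and lower numbers for stronger inhibition. Compound 1 `C/N=C(/S)[C@@]1(c2cccnc2)CCCC[C@@H]1CCOC(C)=O` gives 30 nM in this assay. Compound 2 `C/N=C(/S)[C@@]1(c2cccnc2)CCCC[C@@H]1CCNc1ccccc1` gives 3 nM in this assay. Within the data shown here, the one measured step, a 10-fold lower number from compound 1 to compound 2 (1.00 log units; beyond the scatter), shows that the group at the end of the chain moves the read-out well beyond the scatter. Compound 2 therefore stands as the lowest of the two numbers shown, with compound 1 its only neighbour.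

Compound 3 `C/N=C(/S)[C@@]1(c2cccnc2)CCCC[C@@H]1CCNS(=O)(=O)c1cccnc1` is not yet measured. It differs from compound 2 by (pyridin-3-yl)sulfonyl in place of phenyl on an amine nitrogen. Among the measured compounds shown here, no measured step exchanges a group on this amine nitrogen, so there is no direct guide. The step that touches the same region, a 10-fold lower number from compound 1 to compound 2 (1.00 log units; beyond the scatter), shows only that this end of the molecule can shift the number by a good margin, so a movement of that order in either direction is plausible. Given how much the entering group differs in what it counts from the leaving phenyl, compound 3 is expected to give a somewhat higher number, estimated at 10 nM with a range from 2 nM to 60 nM. That estimate would mean a 3.3-fold higher number from compound 2 to compound 3 (0.52 log units; beyond the scatter).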

Compound 3, concentration for 90% inhibition: 3 nM
Beside the measured number, compound 3's estimate is 3.3-fold (0.52 log units) above it; low and high end bracket the measured number.
By their numbers in this assay, from the lowest: compounds 2 and 3 (each within the scatter of the next); then compound 1.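

In this assay, (pyridin-3-yl)sulfonyl in place of phenyl on the amine nitrogen gives no change at the digits printed from compound 2 to compound 3 (within the scatter), so this position takes a quite different group with no shift that can be told from the scatter. Among these compounds, the earlier step, a 10-fold lower number from compound 1 to compound 2 (1.00 log units; beyond the scatter), showed only that the group at the end of the chain can move the read-out; the new step shows that the number of compound 2 does not require phenyl directly on that nitrogen, as a sulfonyl group and a ring with one hetero atom, with hydrogen-bond acceptors where phenyl has none, leave it in place. Nothing available explains why these two groups read alike.

The compounds shown leave open whether the sulfonyl group or the ring with its hetero atom matters more here: phenylsulfonyl or pyridin-3-yl on the same nitrogen would separate the two. Also open, on these data alone, is how the read-out responds to a simple acetyl group on that amine nitrogen, or to a longer chain leading to it from the saturated ring carbon.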